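A few compounds are considered here, and "the series" means these few. Any claim that something is new, unique, unknown or untested is made for them only; others in the source may bear on it.

- compound 1 `COC1=C(C)C(=O)/C(=C(O)/C=C/c2ccc(F)cc2)C(=O)C1(C)C`: 2.7 ug/mL
- compound 2 `CCc1ccc(/C=C/C(O)=C2/C(=O)C(C)=C(OC)C(C)(C)C2=O)cc1`: 1.9 ug/mL
- compound 3 `COC1=C(C)C(=O)/C(=C(O)/C=C/c2cccc3ccccc23)C(=O)C1(C)C`: 1.3 ug/mL

In a functional assay on KB cells (Homo sapiens) for cytotoxicity (on this read-out lower numbers stand for an effect already at smaller amounts and higher numbers for an effect only at larger amounts of compound), compound 1 gives 2.7 ug/mL and compound 2 gives 1.9 ug/mL, two values within the scatter of each other. Compound 3 gives 1.3 ug/mL, which lies lower than the number for compound 1 by more than the scatter.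

Compound 4 `COC1=C(C)C(=O)/C(=C(O)/C=C/c2ccco2)C(=O)C1(C)C` has not yet been measured. It differs from compound 1 as follows: furan-2-yl in place of 4-fluorophenyl on a double-bonded chain carbon bound to a double-bonded chain carbon. Going by the values given here, only one measured step bears on this aromatic group: a 1.4-fold lower number from compound 1 to compound 2 (0.15 log units; within the scatter), which stays within the scatter. Among the compounds with values here, that step keeps the six-membered ring, however, and no measured compound carries furan-2-yl, so the evidence is indirect. On the strength of that small step, no shift beyond the scatter is expected in this assay, and no direction can be firmly called. The estimated change is a 1.1-fold higher number from compound 1 to compound 4 (0.05 log units; within the scatter). For compound 4 the estimated value is 3 ug/mL, with an expected range from 1.2 ug/mL to 7.5 ug/mL.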

Compound 4, concentration for half-maximal effect: 8.8 ug/mL
The estimate for compound 4 lay 2.9-fold (0.47 log units) below the measured number, and the stated range ends below it.
By their numbers in this assay, from the lowest: compounds 3, 2 and 1 (each within the scatter of the next, the first and the last beyond it); then compound 4.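

In this assay furan-2-yl in place of 4-fluorophenyl gives a 3.3-fold higher number from compound 1 to compound 4 (0.51 log units; beyond the scatter) and furan-2-yl in place of 4-ethylphenyl gives a 4.6-fold higher number from compound 2 to compound 4 (0.67 log units; beyond the scatter) in the same direction. Both steps lie beyond the scatter, whereas the exchange of fluoro for ethyl on the six-membered aromatic ring stayed within it, so this position does respond to a change of the aromatic group itself, and the response here is towards a higher number. No measurement is available that would explain this shift.

The compounds shown leave open whether the step follows the smaller ring or its oxygen, a question that a thiophen-2-yl group at this place could help separate. They also leave open how an amine or a carboxylic acid on the aromatic ring would read in this assay at all.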